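Fluoro for hydrogen on a series pinned at the limit

The source may hold more compounds than are shown below. What is called first, only, known or untested is meant among the compounds shown, and "the series" means these compounds.

Measured compounds:
compound 1 `Cc1c(O)ccc2c1[C@H](Cn1cc(-c3ccccc3)nn1)[C@@]13CC(=O)[C@@](C)(CC[C@@H]21)C3` — in a functional assay on SMMC-7721 cells (Homo sapiens) for cytotoxicity, read by MTT assay, with a stated time of 4 days (on this read-out higher numbers stand for weaker inhibition and lower numbers for stronger inhibition), compound 1 gives > 20000 nM, a limit of the assay.
compound 2 `Cc1c(O)ccc2c1[C@H](Cn1cc(-c3ccc(F)cc3)nn1)[C@@]13CC(=O)[C@@](C)(CC[C@@H]21)C3` — in this assay compound 2 gives > 20000 nM, a limit of the assay.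
compound 3 `C=C1C[C@]23C[C@@]1(O)CC[C@H]2c1cc(Br)c(O)c(C)c1[C@@H]3Cn1cc(-c2ccccc2)nn1` — in this assay compound 3 gives > 20000 nM, a limit of the assay.

The change from compound 1 to compound 2 is fluoro in place of hydrogen on an aromatic carbon. Its step that the two limits leave unreadable from compound 1 to compound 2 cannot be sized, because both ends sit at the limit of > 20000 nM in this assay, at which 3 of the 3 values shown sit. Compound 3 carries the same unsubstituted phenyl as compound 1; the difference between the two cores is not broken down here. Compound 4 `C=C1C[C@]23C[C@@]1(O)CC[C@H]2c1cc(Br)c(O)c(C)c1[C@@H]3Cn1cc(-c2ccc(F)cc2)nn1`, not yet measured, repeats the change on compound 3: fluoro in place of hydrogen on an aromatic carbon. The step from compound 3 to compound 4 is expected to be a step that the limit leaves unreadable from compound 3 to compound 4; this expectation rests on the unsized step that the two limits leave unreadable from compound 1 to compound 2 and on (the limit of > 20000 nM in this assay, at which 3 of the 3 values shown sit). Compound 4 is therefore expected to give 30000 nM in this assay, most likely again as a limit only, within 15000 nM to 100000 nM.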

Compound 4, half-maximal inhibitory concentration: > 20000 nM
Compound 4: only a limit was reported; the forecaster's own chance of this, stated with the estimate: 85%; the middle value is on the limit's open side.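

Compound 3 and compound 4 both stand at a limit in this assay, so the step from phenyl to 4-fluorophenyl cannot be read: the limit of > 20000 nM in this assay, at which 4 of the 4 values shown sit. Still open, from the compounds shown here alone, is whether this change has any size on either core.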